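Back to a Bulkier Triazole Substituent

The compounds below may be only part of what the source reports. "The series", "measured", "known", "first", "only" and "open" are said of these compounds alone.

Compound 1 `Cc1ccc(S(=O)(=O)NCc2cn(C[C@H](O)[C@H]3OC(=O)C(OCc4ccccc4)=C3OCc3ccccc3)nn2)cc1` and compound 2 `O=C1O[C@H]([C@@H](O)Cn2cc(CCO)nn2)C(OCc2ccccc2)=C1OCc1ccccc1` share one core and differ only at the end of the triazole ring. In an ADME assay on HFF cells (Homo sapiens) for cytotoxicity, read by MTT assay, with a stated time of 72 h (on this read-out lower numbers stand for stronger inhibition and higher numbers for weaker inhibition), compound 1 gives 50 nM, while compound 2 gives 58500 nM, which is the highest of the two numbers seen here. Going by the values given here, the single measured step, a 1200-fold higher number from compound 1 to compound 2 (3.07 log units; beyond the scatter), shows that trading the larger group for a short chain raised the number sharply. Compound 3 `CCCCCc1ccc(-c2cn(C[C@H](O)[C@H]3OC(=O)C(OCc4ccccc4)=C3OCc3ccccc3)nn2)cc1` now moves in the other direction: 4-pentylphenyl in place of 2-hydroxyethyl on an aromatic carbon. The step from compound 1 to compound 2 bears on this, since it was a large change when a ring-bearing group was removed from that position, so a large step down is expected when a ring-bearing group is put back. The estimate for compound 3 is 400 nM, within 40 nM to 4000 nM, an expected step of a 150-fold lower number from compound 2 to compound 3 (2.17 log units; beyond the scatter).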

Compound 3, half-maximal inhibitory concentration: > 100000 nM
Compound 3 gave a limit, no number; the forecaster's own chance of this, stated with the estimate: 5%; at least 250-fold (2.39 log units) between middle value and limit.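

Compound 3 reads only as a limit of the assay, not as a number: the limit of > 100000 nM in this assay, at which 1 of the 3 values shown sits.

A ring at this position is therefore not enough to give a low number, as 4-pentylphenyl in place of (((4-methylphenyl)sulfonyl)amino)methyl gives an at least 2000-fold higher number from compound 1 to compound 3 (3.30 log units; beyond the scatter). Against the short 2-hydroxyethyl group the same ring-bearing group gives an at least 1.7-fold higher number from compound 2 to compound 3 (0.23 log units; that floor lies within the scatter), so this floor does not separate those two groups, and of the three compounds only compound 1 reads low.

The compounds shown leave open which part of the ((4-methylphenyl)sulfonyl)amino group goes with the low number, for instance whether a simple amine on the same saturated chain carbon would keep it. They also leave open whether a plain phenyl ring without the pentyl chain would give a number rather than a limit.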